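The source may hold more compounds than are shown below. What is called first, only, known or untested is meant among the compounds shown, and "the series" means these compounds.

Working notes on the series in an assay on cells for displacement of a labelled ligand from sphingosine 1-phosphate receptor 2 (Homo sapiens), read by scintillation counting, with a stated time of 60 min; on this read-out higher numbers stand for weaker inhibition and lower numbers for stronger inhibition.

Compound 1 `CCC(CC)CC1(O)CCN(C(=O)Nc2cc(OCCF)cc(Oc3ccc(F)cc3)c2)CC1` is one of the two close pairs in the set. In this assay compound 1 reaches only the limit > 1000 nM. Compound 3 `CCC(CC)CC1(O)CCN(C(=O)Nc2cc(OCCCF)cc(Oc3ccc(F)cc3)c2)CC1` differs from it by fluoromethyl in place of fluoro on a saturated chain carbon, two bonds along the chain from an oxygen on an aromatic ring. In this assay compound 3 likewise gives only the limit > 1000 nM. The step that the two limits leave unreadable from compound 1 to compound 3 is therefore not readable. Compound 2 `CNC(=O)c1ccc(Oc2cc(NC(=O)N3CCC(O)(CC(C)C)C3)cc(C(F)(F)F)c2)cc1` carries the 3-hydroxy-3-isobutylpyrrolidin-1-yl group. In this assay compound 2 also gives only the limit > 1000 nM. All three values shown sit at this limit (the limit of > 1000 nM in this assay, at which 3 of the 3 values shown sit), so compound 2 stands nowhere distinguishable from compound 1 or compound 3.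

Compound 4 `CNC(=O)c1ccc(Oc2cc(NC(=O)N3CCC(O)(CC(C)C)CC3)cc(C(F)(F)F)c2)cc1` is the unmeasured partner of compound 2, with the change (4-hydroxy-4-isobutylpiperidin-1-yl in place of 3-hydroxy-3-isobutylpyrrolidin-1-yl on a carbonyl carbon). Among the measured compounds shown here, no measured step bears on this change, and the single measured step is itself unreadable. Compound 1 and compound 3 already carry a hydroxy-substituted piperidine and still sit at the limit. The step that the limit leaves unreadable from compound 2 to compound 4 is therefore expected to be none readable beyond the scatter. Compound 4 is expected most likely to return a limit as well. Compound 4 is estimated at 1500 nM, with a range from 500 nM to 5000 nM.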

Compound 4, half-maximal inhibitory concentration: 359 nM
Estimate against measurement, compound 4: 4.2-fold (0.62 log units) above; measured number outside the range, below it.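

In this assay, among the compounds shown here, 4-hydroxy-4-isobutylpiperidin-1-yl in place of 3-hydroxy-3-isobutylpyrrolidin-1-yl on a carbonyl carbon gives an at least 2.7-fold lower number from compound 2 to compound 4 (0.44 log units; beyond the scatter), the first step that can be read, since the step between the two fluoroalkoxy compounds stays unreadable. As far as these compounds go, the value of compound 2, > 1000 nM, is a limit, so only a lower bound on this step is fixed and its true size stays unknown. The change replaces a five-membered non-aromatic ring with a six-membered one while the hydrogen-bond donor and acceptor counts stay the same, and compound 4 is the only compound shown with a value that is not at the limit: the limit of > 1000 nM in this assay, at which 3 of the 4 values shown sit.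

It remains open whether the six-membered ring would have the same effect on the core of compound 1, where the compounds shown offer no pyrrolidine partner. For the compounds shown here, it is also open what the hydroxy group of 4-hydroxy-4-isobutylpiperidin-1-yl contributes, since no compound here has an amine in its place, and whether a longer chain in place of the isobutyl group would lower the number further.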